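Removing the methyl from the methoxy of compound 2

This account rests on a few compounds, and the source may have more. Where it says the series, first, only, none or still open, it means among the compounds named here.

Of the compounds shown here, three have so far been measured in a functional assay on BT-549 cells (Homo sapiens) for inhibition, read by sulforhodamine B assay, with a stated time of 48 h; on this read-out lower numbers stand for stronger inhibition of growth and higher numbers for weaker inhibition of growth. Compound 1 `O=C(Nc1cccc(-n2cc(-c3ccncc3)c(-c3ccc(Cl)c(O)c3)n2)c1)Nc1cccc(C(F)(F)F)c1` gives 21400 nM. Compound 2 `COc1cc(-c2nn(-c3cccc(NC(=O)Nc4cc(C(F)(F)F)cc(C(F)(F)F)c4)c3)cc2-c2ccncc2)ccc1Cl` gives 3060 nM, and compound 3 `COc1cc(-c2nn(-c3cccc(NC(=O)Nc4cccc(C(F)(F)F)c4)c3)cc2-c2ccncc2)ccc1Cl` gives 3810 nM. Compound 2 shows the lowest number of the three, though its gap to compound 3 is within the scatter, while compound 1 stands furthest from it. Compound 4 `O=C(Nc1cccc(-n2cc(-c3ccncc3)c(-c3ccc(Cl)c(O)c3)n2)c1)Nc1cc(C(F)(F)F)cc(C(F)(F)F)c1` differs from compound 2 by hydrogen in place of methyl on an oxygen on an aromatic ring, so that 4-chloro-3-methoxyphenyl becomes 4-chloro-3-hydroxyphenyl. The same change, taken in the opposite direction, appears in the step of a 5.6-fold lower number from compound 1 to compound 3 (0.75 log units; beyond the scatter). The other point on which compound 4 and compound 1 differ, an added trifluoromethyl, is matched by a 1.2-fold higher number from compound 2 to compound 3 (0.10 log units; within the scatter), which changes little. The number for compound 4 in this assay is therefore expected to rise by a 5.6-fold higher number from compound 2 to compound 4 (0.74 log units; beyond the scatter), a modest step beyond the scatter. Compound 4 is estimated at 17000 nM, with a range from 7000 nM to 40000 nM.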

Compound 4, concentration for total growth inhibition: 2120 nM
For compound 4 the middle estimate is 8.0-fold (0.90 log units) above the measured one; measured number below the stated range.
By their numbers in this assay, from the lowest: compounds 4, 2 and 3 (each within the scatter of the next); then compound 1.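

Hydrogen in place of methyl on the oxygen no longer raises the number once the added trifluoromethyl is present, with a 1.4-fold lower number from compound 2 to compound 4 (0.16 log units; within the scatter), so the change from methoxy to hydroxy does not carry over between the two cores: the same change on two cores in this assay, a 5.6-fold lower number (0.75 log units; beyond the scatter) from compound 1 to compound 3 and a 1.4-fold higher number (0.16 log units; within the scatter) from compound 4 to compound 2, 8.1-fold (0.91 log units) apart, beyond the scatter of two such steps

Likewise, the added trifluoromethyl matters on the hydroxy pair, with a 10-fold lower number from compound 1 to compound 4 (1.00 log units; beyond the scatter), and this does not carry over from the methoxy pair: the same change on two cores in this assay, a 1.2-fold higher number (0.10 log units; within the scatter) from compound 2 to compound 3 and a 10-fold higher number (1.00 log units; beyond the scatter) from compound 4 to compound 1, 8.1-fold (0.91 log units) apart, beyond the scatter of two such steps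

The two changes therefore do not act independently in this assay, and compound 1 alone stands apart at 21400 nM.

The compounds shown leave open whether this dependence extends to other groups at the same place, such as an amine in place of the hydroxy or an ethoxy in place of the methoxy. They also do not tell why the two changes depend on each other, or whether the pattern holds in any other cell line.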